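This account rests on a few compounds, and the source may have more. Where it says the series, first, only, none or still open, it means among the compounds named here.

Measured compounds and their numbers in a functional assay on Z-138 cells (Homo sapiens) for inhibition, read by luminescence and CellTiter-Glo, with a stated time of 72 h; on this read-out lower numbers stand for stronger inhibition and higher numbers for weaker inhibition:

Compound 1 `C=CC(=O)Nc1cccc(Cn2nc(-c3ccc(Oc4ccccc4)cc3)cc2C(=O)OCC)c1` gives 7800 nM.
Compound 2 `C=CC(=O)Nc1cccc(Cn2nc(-c3ccc(Oc4ccccc4)cc3)cc2CO)c1` gives 6000 nM.
Compound 3 `O=C(CCl)Nc1cccc(Cn2nc(-c3ccc(Oc4ccccc4)cc3)cc2C(=O)O)c1` gives 9100 nM.

All three numbers lie close together. Within the data shown here, the only single-site step among them, a 1.3-fold lower number from compound 1 to compound 2 (0.11 log units; within the scatter), shows how little the read-out moves here. Compound 3 carries the highest of the three numbers, yet its gaps to compound 1 and to compound 2 are both within the scatter, so no ranking can be drawn from them.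

Compound 4 `C=CC(=O)Nc1cccc(Cn2nc(-c3ccc(Oc4ccccc4)cc3)cc2C(=O)O)c1` differs from compound 3 by vinyl in place of chloromethyl on a carbonyl carbon. Among the measured compounds shown here, no measured pair isolates this exchange, so nothing directly bears on it. What can be said is that compound 1 and compound 2, which both carry the vinylcarbonyl group, give numbers in the same narrow band as compound 3, which carries the (chloromethyl)carbonyl group. On that basis the step from compound 3 to compound 4 is expected to be a 1.1-fold lower number from compound 3 to compound 4 (0.06 log units; within the scatter), that is, no change beyond the scatter. Compound 4 is therefore estimated at 8000 nM in this assay, within a range of 3000 nM to 20000 nM.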

Compound 4, half-maximal inhibitory concentration: 28500 nM
For compound 4 the middle estimate is 3.6-fold (0.55 log units) below the measured one; measured number above the stated range.
By their numbers in this assay, from the lowest: compounds 2, 1 and 3 (each within the scatter of the next); then compound 4.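

In this assay, putting vinyl in place of chloromethyl on a carbonyl carbon, with the carboxy group kept, gives a 3.1-fold higher number from compound 3 to compound 4 (0.50 log units; beyond the scatter) and so weakens inhibition, which shows that this exchange can move the read-out. With the vinylcarbonyl group kept, the carboxy group also separates from the groups it replaces: hydroxymethyl gives way to it in a 4.8-fold higher number from compound 2 to compound 4 (0.68 log units; beyond the scatter) and ethyl gives way to hydrogen in a 3.7-fold higher number from compound 1 to compound 4 (0.56 log units; beyond the scatter) on the way to the same acid. No measurement shown here accounts for either effect.

The compounds shown leave open whether chloromethyl and vinyl would differ in the same way with ethoxycarbonyl or hydroxymethyl on the aromatic carbon. Going by these compounds, how an amine or a primary amide at that carbon, or a longer chain on the carbonyl carbon, would compare also remains open.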